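Second methyl on the sulfonyl aryl ring of compound 3

This account rests on a few compounds, and the source may have more. Where it says the series, first, only, none or still open, it means among the compounds named here.

Compound 2 `CCCCC(CC)C(=O)Nc1ccc2ccn(Cc3ccc(C(=O)NS(=O)(=O)c4ccccc4)cc3OC)c2c1` gives 8.6 in a functional assay (trachea) for antagonist activity, with Cavia porcellus as the target; on this read-out lower numbers stand for lower potency and higher numbers for higher potency (the scale is a negative logarithm). Compound 1 `CCCCC(CC)C(=O)Nc1ccc2ccn(Cc3ccc(C(=O)NS(=O)(=O)c4ccccc4C)cc3OC)c2c1` gives 8.9 in this assay, and the step of a number 0.30 log units higher from compound 2 to compound 1 (within the scatter) is methyl in place of hydrogen on an aromatic carbon, placed on an aromatic carbon of a six-membered aromatic ring of carbon only, ortho to a large group. Compound 3 `COc1cc(C(=O)NS(=O)(=O)c2ccccc2C)ccc1Cn1ccc2ccc(NC(=O)CC3CCCC3)cc21` gives 9.9; the step of a number 1.00 log units higher from compound 1 to compound 3 (beyond the scatter) connects it to compound 1, while the difference between the cores of compound 2 and compound 3 is not broken down here. Compound 4 `COc1cc(C(=O)NS(=O)(=O)c2cc(C)ccc2C)ccc1Cn1ccc2ccc(NC(=O)CC3CCCC3)cc21` carries the same kind of change as compound 1, (methyl in place of hydrogen on an aromatic carbon), but here the place is meta to a large group and para to a methyl group. Because a number 0.30 log units higher from compound 2 to compound 1 (within the scatter) lay within the scatter, compound 4 is expected to show a number 0.20 log units higher from compound 3 to compound 4 (within the scatter), an estimate resting on compound 1 alone. Compound 4 is therefore estimated at 10.1, between 9.5 and 10.7.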

Compound 4, negative logarithm of the antagonist equilibrium constant: 8.4
The estimate for compound 4 lay 1.70 log units above the measured number; the measured number lies below the stated range.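

In this assay, the methyl that turns 2-methylphenyl into 2,5-dimethylphenyl gave a number 1.50 log units lower from compound 3 to compound 4 (beyond the scatter). The same kind of change therefore did not carry from one core to the other in this series: the same change on two cores in this assay, a number 0.30 log units higher (within the scatter) from compound 2 to compound 1 and a number 1.50 log units lower (beyond the scatter) from compound 3 to compound 4, 1.80 log units apart, beyond the scatter of two such steps The two steps differ both in the core and in the place of the methyl, here meta to a large group and para to a methyl group, and these two compounds pairs do not show which of the two differences matters.

As far as these compounds go, it remains open whether 2,5-dimethylphenyl would give a similar step on the core of compound 1. From the compounds shown here alone, it also remains open whether a chlorine or a methoxy group in that same place would behave as the methyl does.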